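The compounds below may be only part of what the source reports. "The series", "measured", "known", "first", "only" and "open" are said of these compounds alone.

Compound 1 `CN(c1ccccc1)S(=O)(=O)C1CC2OC1C(c1ccc(NC(=O)CCCCCCC(=O)O)cc1)=C2c1ccc(O)cc1`: 63800 nM
Compound 2 `Cc1cccc(N(C)S(=O)(=O)C2CC3OC2C(c2ccc(NC(=O)CCCCCCC(=O)O)cc2)=C3c2ccc(O)cc2)c1`: 30200 nM

Within the data shown here, in a functional assay on MCF7 cells (Homo sapiens) for antiproliferative activity, read by MTT assay, with a stated time of 72 h (on this read-out higher numbers stand for weaker inhibition and lower numbers for stronger inhibition), compound 2 holds the lower of the two numbers; its nearest neighbour is compound 1, and the step of a 2.1-fold lower number from compound 1 to compound 2 (0.32 log units; beyond the scatter) is the only measured step. Compound 3 `CCN(c1ccccc1Cl)S(=O)(=O)C1CC2OC1C(c1ccc(NC(=O)CCCCCCC(=O)O)cc1)=C2c1ccc(O)cc1` differs from compound 2 in one place: (2-chlorophenyl)(ethyl)amino in place of methyl(3-methylphenyl)amino on a sulfonyl sulfur. The measured step bears on this only loosely, since it concerned methyl in place of hydrogen on an aromatic carbon, whereas here the methyl(3-methylphenyl)amino leaves as a whole and (2-chlorophenyl)(ethyl)amino enters on the sulfonyl sulfur. Among the measured compounds shown here, no measured step shows what a chlorine or an ethyl does at that place. In this assay compound 2 gives 30200 nM, and compound 3 is expected to lie near it. The step of a 1.2-fold lower number from compound 2 to compound 3 (0.08 log units; within the scatter) is expected to stay within the scatter. The estimate for compound 3 is 25000 nM, with a range from 8000 nM to 80000 nM.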

Compound 3, half-maximal inhibitory concentration: 33300 nM
For compound 3 the middle estimate is 1.3-fold (0.12 log units) below the measured one, within the range that was stated.
By their numbers in this assay, from the lowest: compounds 2, 3 and 1 (each within the scatter of the next, the first and the last beyond it).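

In this assay, putting (2-chlorophenyl)(ethyl)amino in place of methyl(3-methylphenyl)amino on the sulfonyl sulfur gives a 1.1-fold higher number from compound 2 to compound 3 (0.04 log units; within the scatter), so this position takes a different amino group, carrying a chlorine and an ethyl, with no separable effect on the number. Measured against the methyl(phenyl)amino group, the same entering group gives a 1.9-fold lower number from compound 1 to compound 3 (0.28 log units; within the scatter), which also stays within the scatter, even though the step of a 2.1-fold lower number from compound 1 to compound 2 (0.32 log units; beyond the scatter) lies just beyond it. No measurement at hand explains these results.

On these data alone, the chlorine and the ethyl enter together here, and what each does alone remains open. As far as these compounds go, it is also open whether a nitrile or a methoxy on the aromatic ring, or a pyridine ring in place of that ring, would move the number at this position.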